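Taking one hydroxy away from compound 3

This account rests on a few compounds, and the source may have more. Where it says the series, first, only, none or still open, it means among the compounds named here.

Measured values in an ADME assay on L6 cells (Rattus norvegicus) for cytotoxicity; on this read-out lower numbers stand for stronger inhibition and higher numbers for weaker inhibition 
compound 1 `N=C(N)c1ccc(-c2cc3cc(C(=N)N)ccc3o2)cc1` at 1900 nM 
compound 2 `N=C(N)c1ccc(-c2cc3cc(C(=N)N)cc(O)c3o2)cc1` at 184000 nM 
compound 3 `N=C(N)c1ccc(-c2cc3cc(C(=N)N)cc(O)c3o2)c(O)c1` at 2100 nM 

Compound 3 stands level with compound 1 on these numbers, the two values lying within the scatter of each other, while compound 2 carries much the highest number of the three. The move to compound 4 `N=C(N)c1ccc(-c2cc3cc(C(=N)N)ccc3o2)c(O)c1` puts hydrogen in place of hydroxy on an aromatic carbon and alters nothing else.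

Going by the values given here, two measured steps bear on this, and both are large. Adding this same hydroxy gave a 97-fold higher number from compound 1 to compound 2 (1.99 log units; beyond the scatter) so taking it away points towards a lower number. Adding the other hydroxy gave an 88-fold lower number from compound 2 to compound 3 (1.94 log units; beyond the scatter) and compound 4 is compound 1 carrying that other hydroxy alone. Summing the two steps would place compound 4 far under compound 1, yet no measurement shows that they carry over unchanged between these compounds. Only a moderate fall is therefore expected, estimated as a 2.1-fold lower number from compound 3 to compound 4 (0.32 log units; beyond the scatter) in this assay with wide uncertainty. The expected value for compound 4 is 1000 nM with an estimated range from 100 nM to 8000 nM overall.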

Compound 4, half-maximal inhibitory concentration: 33300 nM
Estimate against measurement, compound 4: 33-fold (1.52 log units) below, outside the stated range (above it).
By their numbers in this assay, from the lowest: compounds 1 and 3 (each within the scatter of the next); then compound 4; then compound 2.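

In this assay, taking the hydroxy off this carbon of the fused system gave a 16-fold higher number from compound 3 to compound 4 (1.20 log units; beyond the scatter), so the same hydroxy that had sent the number up on the core of compound 1 brings it down once the other hydroxy is present: the same change on two cores in this assay, a 97-fold higher number (1.99 log units; beyond the scatter) from compound 1 to compound 2 and a 16-fold lower number (1.20 log units; beyond the scatter) from compound 4 to compound 3, 1500-fold (3.19 log units) apart, beyond the scatter of two such steps

The other hydroxy reverses in the same way, giving an 18-fold higher number from compound 1 to compound 4 (1.24 log units; beyond the scatter), against the large fall it produced on the core already carrying the first hydroxy: the same change on two cores in this assay, an 88-fold lower number (1.94 log units; beyond the scatter) from compound 2 to compound 3 and an 18-fold higher number (1.24 log units; beyond the scatter) from compound 1 to compound 4, 1500-fold (3.19 log units) apart, beyond the scatter of two such steps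

Neither hydroxy therefore has a single direction among these compounds, since each one's step depends on whether the other is there, and the numbers of compound 1, with neither, and compound 3, with both, lie within the scatter of each other.

The compounds shown leave open whether this reversal is particular to the pair of hydroxy groups or would also appear with a methoxy group or a fluorine atom at either position. On these data alone, they also give no indication of what makes the two groups depend on each other, and whether the same interplay holds outside this assay remains unknown.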